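Iodo to Ethoxyphenyl on a Benzoyl-Bearing Fused Core

A few compounds are considered here, and "the series" means these few. Any claim that something is new, unique, unknown or untested is made for them only; others in the source may bear on it.

Compound 2 `COC(=O)c1ccc2c(I)cc(C(=O)c3ccccc3)c-2cc1` gives -5.4% in an assay on cells for displacement of a labelled ligand from Orexin receptor type 2 (Homo sapiens), read by scintillation counting, with stated times of 10 min and 90 min, tested at 10 uM (on this read-out higher numbers stand for more inhibition at the one concentration tested (going by the name of the read-out) and lower numbers for less inhibition), and stands at the top of the two numbers measured, with compound 1 `COC(=O)c1ccc2c(C(=O)c3ccccc3)cc(C(=O)c3ccccc3)c-2cc1`, which gives -14.5% in this assay, within the scatter of it. Within the data shown here, the one measured step, a number 9.1 percentage points higher from compound 1 to compound 2 (within the scatter), lies within the scatter. Compound 3 `CCOc1ccc(-c2cc(C(=O)c3ccccc3)c3ccc(C(=O)OC)ccc2-3)cc1` differs from compound 2 thus: 4-ethoxyphenyl in place of iodo on an aromatic carbon. Among the measured compounds shown here, no measured step involves 4-ethoxyphenyl, and the one step known stayed within the scatter, so no step beyond the scatter is expected. Compound 3 is estimated at -5%, between -25% and 15%. That estimate means an expected a number 0.4 percentage points higher from compound 2 to compound 3 (within the scatter).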

Compound 3, a percentage reported as inhibition, at one concentration (the size of the read-out at that concentration, not a potency): 19.1%
For compound 3 the middle estimate is 24.1 percentage points below the measured one; measured number outside the range, above it.
By their numbers in this assay, from the lowest: compounds 1 and 2 (each within the scatter of the next); then compound 3.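

On an aromatic carbon of the five-membered ring, this assay now shows a change that goes beyond the scatter: 4-ethoxyphenyl in place of iodo gives a number 24.5 percentage points higher from compound 2 to compound 3 (beyond the scatter) and 4-ethoxyphenyl in place of benzoyl gives a number 33.6 percentage points higher from compound 1 to compound 3 (beyond the scatter). Iodo and benzoyl had stayed within the scatter of each other here, so this position does respond to the group it carries, at least to 4-ethoxyphenyl. Nothing available explains this rise.

From the compounds shown here alone, it remains open whether the ethoxy group or the added aromatic ring carries the rise, which unsubstituted phenyl would help to separate. Also open, going by these compounds, is how a longer alkoxy chain or an amine in place of the ethoxy group would read.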